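A few compounds are considered here, and "the series" means these few. Any claim that something is new, unique, unknown or untested is made for them only; others in the source may bear on it.

Measured so far in an assay on HEK-293T cells for inhibition of diacylglycerol lipase-alpha (Homo sapiens), read by colorimetric assay; a lower number here means a stronger inhibitor, a higher number a weaker inhibitor:
Compound 1 `O=C(CCCCCCc1ccccc1)c1nnn[nH]1`: > 10000 nM; > 10000 nM (2 entries), both entries a limit.
Compound 2 `O=C(CCCCCCc1ccccc1)c1nc(Br)co1`: > 10000 nM, a limit.
Compound 3 `CC(=O)c1cnc(C(=O)CCCCCCc2ccccc2)o1`: > 10000 nM, a limit.

Compound 3 stands on a limit only, so no number places it relative to the others. Among the measured compounds shown here, the two entries for compound 1 and the single entry for compound 2 are likewise limits, and the whole set sits at the limit of > 10000 nM in this assay, at which 2 of the 3 values shown sit, with no measurable difference between any two members. For the measured compounds named here, no step between measured compounds can therefore be sized, and nothing here separates one member of the series from another.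

Compound 4 `COc1cnc(C(=O)CCCCCCc2ccccc2)o1` is not yet measured in this assay. It differs from compound 3 by methoxy in place of acetyl on an aromatic carbon; in words, methoxy in place of acetyl on an aromatic carbon. Going by the values given here, no measured step is available to size this change, so the step is expected to be a step that the limit leaves unreadable from compound 3 to compound 4, which is no more than the scatter would cover, in no particular direction. Compound 4 is expected at 15000 nM with a range from 3000 nM to 60000 nM, and the most likely outcome is once more a limit rather than a number.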

Compound 4, half-maximal inhibitory concentration: > 10000 nM
Compound 4: only a limit was reported; the forecaster's own chance of this, stated with the estimate: 75%; the middle value does not contradict the limit.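

In this assay compound 4 gives only a limit, as do compound 2 and compound 3, so the steps from each of them to compound 4 cannot be read. The series stays at a single limit: the limit of > 10000 nM in this assay, at which 3 of the 4 values shown sit. The compounds shown leave open whether any change to the shared core gives a measurable value in this assay.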